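Aryl swap at the shared core: outlook for compound 4

A few compounds are considered here, and "the series" means these few. Any claim that something is new, unique, unknown or untested is made for them only; others in the source may bear on it.

Measured compounds:
compound 1 `CCOC(=O)c1c(C)[nH]c(=O)c(C#N)c1-c1ccc(C)cc1` — 11900 nM
compound 2 `CCOC(=O)c1c(C)[nH]c(=O)c(C#N)c1-c1ccc([N+](=O)[O-])cc1` — 21700 nM
compound 3 `CCOC(=O)c1c(C)[nH]c(=O)c(C#N)c1-c1ccc(C#N)cc1` — 20200 nM

In a functional assay on HepG2 cells (Homo sapiens) for inhibition, read by MTT assay, with a stated time of 24 h (a higher number here means a weaker inhibitor, a lower number a stronger inhibitor), compound 1 gives the lowest number of the three, yet the steps of a 1.7-fold higher number from compound 1 to compound 3 (0.23 log units; within the scatter) and a 1.8-fold higher number from compound 1 to compound 2 (0.26 log units; within the scatter) both fall within the scatter, so no order among the three compounds can be drawn. Compound 4 `CCOC(=O)c1c(C)[nH]c(=O)c(C#N)c1-c1ccco1` differs from compound 1 by furan-2-yl in place of 4-methylphenyl on an aromatic carbon. For the measured compounds named here, no measured step exchanges this ring itself; the two steps from compound 1 change only a group on the 4-methylphenyl ring, and the step of a 1.1-fold lower number from compound 2 to compound 3 (0.03 log units; within the scatter) likewise stays within the scatter. A step beyond the scatter in this assay is therefore not expected for compound 4, so the estimated change is a 1.3-fold higher number from compound 1 to compound 4 (0.10 log units; within the scatter). Compound 4 is expected to give 15000 nM, with a range of 5000 nM to 45000 nM.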

Compound 4, half-maximal inhibitory concentration: 57400 nM
For compound 4 the middle estimate is 3.8-fold (0.58 log units) below the measured one; measured number outside the range, above it.
By their numbers in this assay, from the lowest: compounds 1, 3 and 2 (each within the scatter of the next); then compound 4.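

In this assay, for the compounds shown here, replacing the ring itself, opposite the ring nitrogen, gives the first step beyond the scatter: a 4.8-fold higher number from compound 1 to compound 4 (0.68 log units; beyond the scatter). The earlier steps shown here changed only a group on the 4-methylphenyl ring and stayed within the scatter, so at this position the identity of the ring matters more than those changes of group did. Nothing available accounts for the change. On these data alone, whether the higher number goes with the five-membered ring or with its oxygen stays open; a thiophen-2-yl group would separate the two. As far as these compounds go, how a phenyl ring carrying an amine would behave also remains open.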